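Changing the aryl group on the shared core

The compounds below may be only part of what the source reports. "The series", "measured", "known", "first", "only" and "open" are said of these compounds alone.

Values in a functional assay on MCF7 cells (Homo sapiens) for antiproliferative activity, read by MTT assay, with a stated time of 72 h (on this read-out higher numbers stand for weaker inhibition and lower numbers for stronger inhibition), for the measured compounds:
compound 1 (`COc1ccccc1-c1ccc2ncn(-c3cc(OC)c(OC)c(OC)c3)c2c1`) gives 1750 nM
compound 2 (`COc1cc(-n2cnc3ccc(-c4cccc(N)c4)cc32)cc(OC)c1OC`) gives 180 nM

Compound 2 holds the lower number of the two, and compound 1 sits above it by a margin beyond the scatter. The next entry, compound 3 (`COc1cc(-n2cnc3ccc(-c4ccc(C)cc4)cc32)cc(OC)c1OC`), keeps the shared core and carries 4-methylphenyl in place of 3-aminophenyl on an aromatic carbon. Within the data shown here, only one measured step bears on this change (a 9.7-fold lower number from compound 1 to compound 2 (0.99 log units; beyond the scatter)), where 3-aminophenyl replaced 2-methoxyphenyl on an aromatic carbon. Among the measured compounds shown here, that single step shows that the number can move with this group, but no measured compound carries 4-methylphenyl, so its direction does not transfer directly. For the measured compounds named here, compound 2 at 180 nM is the lower of only two values, so a move towards a higher number is expected, smaller than the measured step. The expected change is a 2.2-fold higher number from compound 2 to compound 3 (0.35 log units; beyond the scatter) as a middle estimate, with wide uncertainty. Compound 3 is estimated at 400 nM (expected range 110 nM to 1500 nM).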

Compound 3, half-maximal inhibitory concentration: 110 nM
The estimate for compound 3 lay 3.6-fold (0.56 log units) above the measured number; low and high end bracket the measured number.
By their numbers in this assay, from the lowest: compounds 3 and 2 (each within the scatter of the next); then compound 1.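

Replacing 3-aminophenyl with 4-methylphenyl on this aromatic carbon gives a 1.6-fold lower number from compound 2 to compound 3 (0.21 log units; within the scatter) in this assay and so does not separate the two compounds. The position therefore holds its low number in this assay with a group that has no nitrogen and no hydrogen-bond donor or acceptor, so among the compounds shown the amine is not needed for it. Against 2-methoxyphenyl the same replacement gives a 16-fold lower number from compound 1 to compound 3 (1.20 log units; beyond the scatter) and leaves compound 1 as the only one of the three standing apart, with the two other aryl groups together on the low side. No measured data on hand account for these differences.

Each of the three aryl groups differs from the others both in its substituent and in where that substituent sits, so the compounds shown cannot separate these two factors. Also open, going by these compounds, is how the number responds at this position to a phenyl without any substituent, or to a carboxylic acid or a longer alkyl chain in place of the methyl of 4-methylphenyl.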